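Swapping the amine on a three-carbon chain for a ring

A few compounds are considered here, and "the series" means these few. Any claim that something is new, unique, unknown or untested is made for them only; others in the source may bear on it.

Measured so far:
- compound 1 `O=c1cc(-c2ccccc2)oc2cc(OCc3ccccc3)c(OCCCN3CCCC3)c(O)c12`: 1400 nM
- compound 2 `CCN(CC)CCCOc1c(OC)cc2oc(-c3ccccc3)cc(=O)c2c1O`: 4900 nM
- compound 3 `CN(C)CCCOc1c(OCc2ccccc2)cc2oc(-c3ccccc3)cc(=O)c2c1O`: 2600 nM

All three share one core, and each was tested in a functional assay on A549 cells (Homo sapiens) for antiproliferative activity, read by MTT assay, with a stated time of 48 h; on this read-out higher numbers stand for weaker inhibition and lower numbers for stronger inhibition. Compound 2 gives the highest of the three numbers, with 4900 nM. Its nearest neighbour is compound 3, which gives 2600 nM, a gap within the scatter; the furthest is compound 1, which gives 1400 nM, a gap beyond the scatter.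

Compound 4 `COc1cc2oc(-c3ccccc3)cc(=O)c2c(O)c1OCCCN1CCCCC1` has not been measured. It differs from compound 2 in one place: piperidin-1-yl in place of diethylamino on a saturated chain carbon, three bonds along the chain from an oxygen on an aromatic ring

Among the measured compounds shown here, the only measured step that bears on this change is the one between compound 1 and compound 3, where a ring amine on the same chain gives way to an acyclic one: a 1.9-fold higher number from compound 1 to compound 3 (0.27 log units; within the scatter). Read in the opposite direction, acyclic to ring, that step hints at a slightly lower number, but it stays within the scatter, so no step beyond the scatter is expected in this assay. For the measured compounds named here, compound 2 and compound 4 carry a methoxy where compound 1 and compound 3 carry a benzyloxy, and no measured pair tests the amine swap on that background.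

For compound 4 the expected value in this assay is therefore 3500 nM, with a range from 1500 nM to 9000 nM, which means an expected step of a 1.4-fold lower number from compound 2 to compound 4 (0.15 log units; within the scatter).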

Compound 4, half-maximal inhibitory concentration: 17000 nM
Estimate against measurement, compound 4: 4.9-fold (0.69 log units) below; measured number outside the range, above it.
By their numbers in this assay, from the lowest: compounds 1, 3 and 2 (each within the scatter of the next, the first and the last beyond it); then compound 4.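

Among the compounds shown here, changing 3-(diethylamino)propyl to 3-(piperidin-1-yl)propyl on the methoxy-bearing core gives a 3.5-fold higher number from compound 2 to compound 4 (0.54 log units; beyond the scatter) in this assay, the first amine swap here to move the number beyond the scatter. The earlier step, a 1.9-fold higher number from compound 1 to compound 3 (0.27 log units; within the scatter), stayed within the scatter, so the amine on this chain now proves able to matter, and a ring amine in place of an open-chain one does not by itself go with a lower number. Nothing available here explains why the number rises with this change.

As far as these compounds go, the two steps differ both in the amines involved and in the group on the core, methoxy in one and benzyloxy in the other, so it stays open whether piperidin-1-yl would also give a higher number on the benzyloxy-bearing core, and how pyrrolidin-1-yl would read on the methoxy-bearing one. Also open, from the compounds shown here alone, is how a morpholin-4-yl group, or a longer chain such as 4-(piperidin-1-yl)butyl, would read in this assay.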